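The source may hold more compounds than are shown below. What is called first, only, known or untested is meant among the compounds shown, and "the series" means these compounds.

Working notes on the series.

Compound 1, `ClCc1ccccc1Cn1cnc2c(Cl)nc(Cl)nc21`, is the reference for the dichloro pattern on the shared core. In a functional assay on PC-3 cells (Homo sapiens) for cytotoxicity, read by sulforhodamine B assay, with a stated time of 48 h (a lower number here means that less compound is tolerated, a higher number that more compound is tolerated), compound 1 gives 5120 nM. For the measured compounds named here, compound 2, `ClCc1ccccc1Cn1cnc2c(Cl)ncnc21`, keeps the same substituted benzyl group but carries only one chloro on the core; in this assay compound 2 gives 53700 nM. The change from compound 2 to compound 1 is chloro in place of hydrogen on an aromatic carbon, and it gives a 10-fold lower number from compound 2 to compound 1 (1.02 log units; beyond the scatter).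

Compound 3, `ClCc1cccc(Cn2cnc3c(Cl)ncnc32)c1`, has the same atoms as compound 2 joined differently; how the two cores differ is not broken down here. In this assay, going by the values given here, compound 3 gives 67600 nM, a value that sits within the scatter of the one for compound 2, so no order between these two can be read.

Compound 4, `ClCc1cccc(Cn2cnc3c(Cl)nc(Cl)nc32)c1`, has not been measured. Compared with compound 3 the change is chloro in place of hydrogen on an aromatic carbon. The place of this change is described in the same words as for the step from compound 2 to compound 1, so it is the same change made on a different benzyl arrangement. Given that compound 2 and compound 3 are indistinguishable within the scatter, the expectation rests on the single earlier step of a 10-fold lower number from compound 2 to compound 1 (1.02 log units; beyond the scatter) carrying over. The expected step is a 10-fold lower number from compound 3 to compound 4 (1.02 log units; beyond the scatter), taken as close to that earlier one. Among the compounds with values here, for compound 4 in this assay the estimate is 6500 nM, with a range expected from 2500 nM to 17000 nM; only one prior example of this change exists, so the range is kept wide.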

Compound 4, concentration lethal to 50% of the cells: 55000 nM
Beside the measured number, compound 4's estimate is 8.5-fold (0.93 log units) below it; the measured number lies above the stated range.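

In this assay the chloro entering on the aromatic carbon gives a 1.2-fold lower number from compound 3 to compound 4 (0.09 log units; within the scatter), so on the core of compound 3 this change leaves no difference that can be read. Set beside the earlier step, the same change does not carry over as a fixed step from one core to the other: the same change on two cores in this assay, a 10-fold lower number (1.02 log units; beyond the scatter) from compound 2 to compound 1 and a 1.2-fold lower number (0.09 log units; within the scatter) from compound 3 to compound 4, 8.5-fold (0.93 log units) apart, beyond the scatter of two such steps. This shows that, within these four compounds, the size of the step depends on which of the two cores carries it, but it rests on a single pair per core, so it does not show what sets the two steps apart and gives no rule for any other core.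

As far as these compounds go, it remains open whether an amine or a methoxy group entering at the same place, between two ring nitrogen atoms, would also give steps that differ between the two cores, or whether this gap is confined to chloro. It is equally open whether the gap would persist if the chlorine of the benzyl substituent gave way to a hydroxyl group or a longer chain, since every compound shown keeps that chlorine.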